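Trimethoxyphenyl Takes the Hydrazone Aryl Position

The compounds below may be only part of what the source reports. "The series", "measured", "known", "first", "only" and "open" are said of these compounds alone.

Among the measured compounds shown here, in a functional assay on MKN-45 cells (Homo sapiens) for cytotoxicity, read by MTT assay, with a stated time of 72 h (on this read-out higher numbers stand for weaker inhibition and lower numbers for stronger inhibition), compound 2 `CN(C)CCn1cnnc1-c1cc(Oc2ccc(NC(=O)N/N=C/c3ccc(O)c(Br)c3)cc2F)ccn1` gives 1860 nM, the higher of the two numbers so far, while compound 1 `CN(C)CCn1cnnc1-c1cc(Oc2ccc(NC(=O)N/N=C/c3c(Cl)cccc3Cl)cc2F)ccn1` gives 160 nM. For the measured compounds named here, the only measured step, a 12-fold higher number from compound 1 to compound 2 (1.07 log units; beyond the scatter), shows that the aryl group on the carbon double-bonded to nitrogen shifts this read-out by a wide margin. Compound 3 `COc1ccc(/C=N/NC(=O)Nc2ccc(Oc3ccnc(-c4nncn4CCN(C)C)c3)c(F)c2)c(OC)c1OC` carries 2,3,4-trimethoxyphenyl in place of 3-bromo-4-hydroxyphenyl on a carbon with a double bond to nitrogen. Going by the values given here, no measured step covers this change, so its direction is open, though a shift beyond the scatter is plausible. Compound 3 is expected to give 1000 nM, within 200 nM to 5000 nM. That estimate means an expected step of a 1.9-fold lower number from compound 2 to compound 3 (0.27 log units; within the scatter).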

Compound 3, half-maximal inhibitory concentration: 2020 nM
The estimate for compound 3 lay 2.0-fold (0.31 log units) below the measured number; the measured number falls inside the stated range.
By their numbers in this assay, from the lowest: compound 1; then compounds 2 and 3 (each within the scatter of the next).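

In this assay the step of a 1.1-fold higher number from compound 2 to compound 3 (0.04 log units; within the scatter) places 2,3,4-trimethoxyphenyl level with 3-bromo-4-hydroxyphenyl on a carbon with a double bond to nitrogen, despite their different counts of hydrogen-bond donors and acceptors. The step of a 13-fold higher number from compound 1 to compound 3 (1.10 log units; beyond the scatter) then shows that a second replacement of 2,6-dichlorophenyl also ends far from compound 1, which now stands apart from both others. No evidence on the cause is at hand. On these data alone, whether the two chlorine atoms are needed stays open. How a plain phenyl, a 2-chlorophenyl or an aminophenyl would read at this position is also unknown.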